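The source may hold more compounds than are shown below. What is called first, only, known or untested is meant among the compounds shown, and "the series" means these compounds.

Measured so far:
Compound 1 `O=C1O/C(=C\Cn2cc(-c3cc(F)cc(F)c3)nn2)C(OCc2ccccc2)=C1OCc1ccccc1`. In an ADME assay on HFF cells (Homo sapiens) for cytotoxicity, read by MTT assay, with a stated time of 72 h (on this read-out higher numbers stand for weaker inhibition and lower numbers for stronger inhibition), compound 1 gives > 100000 nM, which is a limit of the assay and not a number.
Compound 2 `CCCCCCCCCCc1cn(C[C@H](O)[C@H]2OC(=O)C(OCc3ccccc3)=C2OCc2ccccc2)nn1`. In this assay compound 2 gives > 100000 nM, likewise a limit and not a number.

Compound 2 stands at the limit (the limit of > 100000 nM in this assay, at which 2 of the 2 values shown sit); no numbered value exists in this set, so nothing orders the two compounds. Among the measured compounds shown here, no step between measured compounds that differ in one place is available, so no measured step size guides the series.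

Compound 3 `Cc1ccc(-c2cn(C[C@H](O)[C@H]3OC(=O)C(OCc4ccccc4)=C3OCc3ccccc3)nn2)cc1`, not yet measured, differs from compound 2 by 4-methylphenyl in place of decyl on an aromatic carbon. With both measured compounds returning only a limit in this assay, the expected step from compound 2 to compound 3 is a number no higher from compound 2 to compound 3 (the limit leaves the size open), none beyond the scatter, and a limit is again the most likely outcome. Compound 3 is expected at 100000 nM in this assay, with a range from 30000 nM to 300000 nM.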

Compound 3, half-maximal inhibitory concentration: > 100000 nM
Compound 3: no number, only a limit (the forecaster's own chance of this, stated with the estimate: 85%); the middle value lies on the limit itself.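

Compound 2 and compound 3 each return only a limit, not a number, in this assay, so no step can be read for 4-methylphenyl in place of decyl: the limit of > 100000 nM in this assay, at which 3 of the 3 values shown sit.

The compounds shown leave open how they order among themselves and whether any change on the shared core gives a numbered value.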